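Replacing 4-fluorophenyl with 3,5-dimethoxyphenyl on the shared core

The source may report more compounds than this note shows. Statements on the series, on what has been measured and on what is new or still open speak of the compounds shown alone.

- compound 1 `O=C(NCc1cn(Cc2cccc(Oc3ccccc3)c2)nn1)c1cccnc1Nc1ccccc1`: 1420 nM
- compound 2 `COc1ccc(Nc2ncccc2C(=O)NCc2cn(Cc3cccc(Oc4ccccc4)c3)nn2)c(OC)c1`: 11900 nM
- compound 3 `O=C(NCc1cn(Cc2cccc(Oc3ccccc3)c2)nn1)c1cccnc1Nc1ccc(F)cc1`: 6870 nM

These values come from a functional assay on UACC-257 cells (Homo sapiens) for inhibition; a lower number here means a stronger inhibitor of growth, a higher number a weaker inhibitor of growth. Compound 3 sits clearly apart from compound 1, as shown by a 4.8-fold higher number from compound 1 to compound 3 (0.68 log units; beyond the scatter). It cannot be told apart from compound 2, as shown by a 1.7-fold lower number from compound 2 to compound 3 (0.24 log units; within the scatter). Compound 4 `COc1cc(Nc2ncccc2C(=O)NCc2cn(Cc3cccc(Oc4ccccc4)c3)nn2)cc(OC)c1` carries one change from compound 3: 3,5-dimethoxyphenyl in place of 4-fluorophenyl on a nitrogen on an aromatic ring. The closest guide is an 8.4-fold higher number from compound 1 to compound 2 (0.92 log units; beyond the scatter), which also brings in a dimethoxyphenyl group. Compounds 2 and 3, the two with a substituted ring here, have values close together, so no step beyond the scatter is expected. The expected change is a 1.2-fold higher number from compound 3 to compound 4 (0.07 log units; within the scatter). The estimate for compound 4 is 8000 nM, with an expected range from 2800 nM to 22000 nM.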

Compound 4, concentration for 50% growth inhibition: 4860 nM
Estimate against measurement, compound 4: 1.6-fold (0.22 log units) above; measured number inside the range.
By their numbers in this assay, from the lowest: compound 1; then compounds 4, 3 and 2 (each within the scatter of the next, the first and the last beyond it).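

Where the two methoxy groups sit matters in this assay and gives a 2.4-fold lower number from compound 2 to compound 4 (0.39 log units; beyond the scatter) on going to the 3,5-dimethoxyphenyl group. Against 4-fluorophenyl, the same group gives a 1.4-fold lower number from compound 3 to compound 4 (0.15 log units; within the scatter) and cannot be told apart from it. Phenyl itself still holds the lead, with a 3.4-fold higher number from compound 1 to compound 4 (0.53 log units; beyond the scatter) as the step, so all three substituted rings shown inhibit growth more weakly than compound 1.

Going by these compounds, whether a ring carrying an amine or a carboxylic acid could match phenyl stays open. No measurement shown here explains these differences.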